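Pyridin-3-yl in place of pyridin-2-yl: working notes

The compounds below may be only part of what the source reports. "The series", "measured", "known", "first", "only" and "open" are said of these compounds alone.

Of the compounds shown here, three sharing one core have been read in a functional assay on B16-F10 cells (Mus musculus) for antiproliferative activity, read by MTT assay, with a stated time of 48 h; on this read-out lower numbers stand for stronger inhibition and higher numbers for weaker inhibition. Compound 1 (`CC(=O)N1N=C(c2ccc3ccccc3c2)OC1c1ccccc1Br`) gives 6.98 ug/mL, compound 2 (`CC(=O)N1N=C(c2ccc3ccccc3c2)OC1c1ccc([N+](=O)[O-])cc1`) gives 9.32 ug/mL, and compound 3 (`CC(=O)N1N=C(c2ccc3ccccc3c2)OC1c1ccccn1`) gives 7.18 ug/mL. Compound 3 cannot be separated from either neighbour: the steps are a 1.0-fold higher number from compound 1 to compound 3 (0.01 log units; within the scatter) and a 1.3-fold lower number from compound 2 to compound 3 (0.11 log units; within the scatter). The third step in the set, a 1.3-fold higher number from compound 1 to compound 2 (0.13 log units; within the scatter), is also within the scatter.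

Next in line is compound 4 (`CC(=O)N1N=C(c2ccc3ccccc3c2)OC1c1cccnc1`), which carries pyridin-3-yl in place of pyridin-2-yl on a saturated ring carbon. The two compounds have the same atoms, joined differently.

All three measured steps are changes at this same ring carbon, and each exchanges one whole group for another. None of them moves this assay beyond the scatter, so the number has so far not responded to changes at this position. Among the measured compounds shown here, no measured pair isolates a shift of the nitrogen within the pyridine ring, so this evidence is indirect and gives no direction.

The expected change is no step beyond the scatter, estimated as a 1.0-fold higher number from compound 3 to compound 4 (0.02 log units; within the scatter). For compound 4 the estimated value is 7.5 ug/mL, with an expected range of 4.5 ug/mL to 12.5 ug/mL.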

Compound 4, half-maximal inhibitory concentration: 3.06 ug/mL
Estimate against measurement, compound 4: 2.5-fold (0.39 log units) above; measured number outside the range, below it.
By their numbers in this assay, from the lowest: compound 4; then compounds 1, 3 and 2 (each within the scatter of the next).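

In this assay, among the compounds shown here, this ring carbon does respond after all: moving the nitrogen within the pyridine ring gives a 2.3-fold lower number from compound 3 to compound 4 (0.37 log units; beyond the scatter) and is the first change at this position to go beyond the scatter, although pyridin-2-yl and pyridin-3-yl have the same heavy-atom, donor and acceptor counts. Compound 4 also separates from the two other groups, with a 3.0-fold lower number from compound 2 to compound 4 (0.48 log units; beyond the scatter) and a 2.3-fold lower number from compound 1 to compound 4 (0.36 log units; beyond the scatter), while 2-bromophenyl, 4-nitrophenyl and pyridin-2-yl remain within the scatter of one another, so the number depends on which group sits here in at least this one case, and compound 4 has the lowest number of the four. No measurement at hand bears on the reason for this separation.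

The compounds shown leave open whether pyridin-4-yl, or a phenyl ring carrying an amine or a carboxylic acid, at this ring carbon would extend the step or fall back among compounds 1, 2 and 3. They also leave open whether the step between pyridin-2-yl and pyridin-3-yl holds when the acetyl group is replaced by a longer acyl chain.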